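This account rests on a few compounds, and the source may have more. Where it says the series, first, only, none or still open, it means among the compounds named here.

In an ADME assay on Akata cells (Homo sapiens) for cytotoxicity, with a stated time of 7 days (on this read-out higher numbers stand for lower toxicity in this test and lower numbers for higher toxicity in this test), compound 1, `CN(C)c1nc(N)nc2c1ncn2/C=C1/CC1(CO)CO`, gives only a limit, > 24000 nM. Compound 2, `CCCSc1nc(N)nc2c1ncn2/C=C1/CC1(CO)CO`, likewise gives only a limit in this assay, > 20000 nM. Compound 3, `Nc1nc2c(ncn2/C=C2/CC2(CO)CO)c(=O)[nH]1`, also gives only a limit in this assay, > 20000 nM. Compound 2 thus stands at the limit, as do both other values shown: the limit of > 20000 nM in this assay, at which 2 of the 3 values shown sit, and (the limit of > 24000 nM in this assay, at which 1 of the 3 values shown sits). Going by the values given here, the one step between measured compounds, a step that the two limits leave unreadable from compound 1 to compound 2, is of unknown size for the same reason. Compound 4, `CCCCCOc1nc(N)nc2c1ncn2/C=C1/CC1(CO)CO`, differs from compound 2 by pentyloxy in place of propylsulfanyl on an aromatic carbon. Among the compounds with values here, no measured step gives a direction for such a change, and no value shown reaches a number, so no step beyond the scatter is expected. Compound 4 is expected to give about 30000 nM, between 15000 nM and 100000 nM. The step this estimate means is a step that the limit leaves unreadable from compound 2 to compound 4.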

Compound 4, half-maximal cytotoxic concentration: > 20000 nM
Compound 4 was reported as a limit; the forecaster's own chance of this, stated with the estimate: 80%; the middle value does not contradict the limit.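

Going by these compounds alone, compound 4, like compound 1 and compound 2, gives only a limit, and no step to compound 4 from either can be read. The compounds shown leave open at what concentration any of them would become toxic in this assay.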